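From cyanopiperidine to phenyl on the shared core

The source may report more compounds than this note shows. Statements on the series, on what has been measured and on what is new or still open speak of the compounds shown alone.

Measured so far in a physicochemical assay for solubility, in phosphate buffer, at pH 7.4; on this read-out higher numbers stand for higher solubility and lower numbers for lower solubility:
Compound 1 `OCCC1CCN(c2nccnc2OC2CN(c3ccc4ccccc4n3)C2)CC1` gives 84000 nM
Compound 2 `OCC1CCN(c2nccnc2OC2CN(c3ccc4ccccc4n3)C2)C1` gives 167000 nM
Compound 3 `N#CC1CCN(c2nccnc2OC2CN(c3ccc4ccccc4n3)C2)CC1` gives 66000 nM

Compound 3 stands at the low end of this small set, level with compound 1. The gap to one neighbour is a 1.3-fold lower number from compound 1 to compound 3 (0.10 log units; within the scatter) and the gap to the other is a 2.5-fold lower number from compound 2 to compound 3 (0.40 log units; beyond the scatter) in this set.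

Compound 4 `c1ccc(-c2nccnc2OC2CN(c3ccc4ccccc4n3)C2)cc1` is still unmeasured and has phenyl in place of 4-cyanopiperidin-1-yl on an aromatic carbon, with phenyl in place of 4-cyanopiperidin-1-yl on an aromatic carbon as the counted difference.

Every measured step keeps a non-aromatic ring at this place, so none of them tests an aromatic ring there. Only loose guidance comes from a 2.5-fold lower number from compound 2 to compound 3 (0.40 log units; beyond the scatter) as the largest of them, and from a 2.0-fold higher number from compound 1 to compound 2 (0.30 log units; within the scatter) as another. Phenyl is new here, so a somewhat larger step in this assay toward a lower number is expected, as a judgement and not a measured trend. The estimated step is a 2.6-fold lower number from compound 3 to compound 4 (0.42 log units; beyond the scatter) on this thin evidence. Compound 4 is estimated at 25000 nM with an expected range from 6000 nM to 80000 nM on this read-out.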

Compound 4, solubility: < 1000 nM
Compound 4: only a limit was reported (the forecaster's own chance of this, stated with the estimate: 10%); at least 25-fold (1.39 log units) between middle value and limit.
By their numbers in this assay, from the lowest: compounds 3, 1 and 2 (each within the scatter of the next, the first and the last beyond it). At a limit, below all of these: compound 4.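

In this assay compound 4 gives only a limit, not a number: the limit of < 1000 nM in this assay, at which 1 of the 4 values shown sits.

Putting phenyl on this aromatic carbon in place of a non-aromatic ring gives very large steps: an at least 66-fold lower number from compound 3 to compound 4 (1.81 log units; beyond the scatter), an at least 84-fold lower number from compound 1 to compound 4 (1.92 log units; beyond the scatter) and an at least 160-fold lower number from compound 2 to compound 4 (2.22 log units; beyond the scatter). Swaps among the non-aromatic rings moved the number far less, the largest being a 2.5-fold lower number from compound 2 to compound 3 (0.40 log units; beyond the scatter), so this position is much more sensitive in this assay to the change to phenyl than to those swaps.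

The compounds shown do not separate the effect of the aromatic ring from the loss of the nitrile and the ring nitrogen of 4-cyanopiperidin-1-yl. They also leave open how a pyridyl ring, or a phenyl carrying an amine or a carboxylic acid, would read at this place.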